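Piperidine in place of methylpiperazine on two related cores

The compounds below may be only part of what the source reports. "The series", "measured", "known", "first", "only" and "open" are said of these compounds alone.

Compound 1 `CCN1C(=O)CN(C2CCCC2)c2nc(Nc3ccc(N4CCN(C)CC4)cc3)ncc21` carries a 4-methylpiperazin-1-yl group on a six-membered aromatic ring of carbon only. In a functional assay on MDA-MB-231 cells (Homo sapiens) for inhibition, read by MTT assay, with a stated time of 48 h (on this read-out higher numbers stand for weaker inhibition and lower numbers for stronger inhibition), compound 1 gives 26200 nM. Compound 2 `CCN1C(=O)CN(C2CCCC2)c2nc(Nc3ccc(N4CCCCC4)cc3)ncc21` differs from it by piperidin-1-yl in place of 4-methylpiperazin-1-yl on an aromatic carbon. In this assay compound 2 gives > 30000 nM, which is a limit of the assay rather than a number, and (the limit of > 30000 nM in this assay, at which 1 of the 3 values shown sits). The step is an at least 1.1-fold higher number from compound 1 to compound 2 (0.05 log units; that floor lies within the scatter), so the change did not sharpen inhibition here.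

Compound 3 `CCN1C(=O)CN(C2CCCC2)c2nc(Nc3ccc(N4CCN(C)CC4)cn3)ncc21` has the same 4-methylpiperazin-1-yl group, but on a six-membered aromatic ring with 1 nitrogen. How its core differs from that of compound 1 is not broken down here. In this assay compound 3 gives 24100 nM, which sits within the usual scatter of the value for compound 1.

Compound 4 `CCN1C(=O)CN(C2CCCC2)c2nc(Nc3ccc(N4CCCCC4)cn3)ncc21` is not yet measured. It differs from compound 3 by piperidin-1-yl in place of 4-methylpiperazin-1-yl on an aromatic carbon. This is the same kind of change as that from compound 1 to compound 2, but here the place is on a ring with 1 nitrogen, two atoms from the ring nitrogen, rather than on a ring of carbon only.

Because the step of an at least 1.1-fold higher number from compound 1 to compound 2 (0.05 log units; that floor lies within the scatter) reached only a limit, the step of a 1.5-fold higher number from compound 3 to compound 4 (0.16 log units; within the scatter) from compound 3 to compound 4 is expected to be of similar kind. Compound 4 is estimated at 35000 nM, with a likely range from 18000 nM to 80000 nM, and a good chance that only a limit is reported.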

Compound 4, half-maximal inhibitory concentration: 28200 nM
Estimate against measurement, compound 4: 1.2-fold (0.09 log units) above; the range from low to high includes it.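

The new step is a 1.2-fold higher number from compound 3 to compound 4 (0.07 log units; within the scatter) in this assay, so replacing 4-methylpiperazin-1-yl with piperidin-1-yl makes no readable difference on the core of compound 3. As far as the data can be read, this absence of a clear step carries across both cores in this small series: the same change on two cores in this assay, an at least 1.1-fold higher number (0.05 log units; that floor lies within the scatter) from compound 1 to compound 2 and a 1.2-fold higher number (0.07 log units; within the scatter) from compound 3 to compound 4; the limit leaves it open whether they differ. This does not show that the two steps are equal or that the change would be equally silent on other cores, since the value for compound 2 is a limit and not a number: the limit of > 30000 nM in this assay, at which 1 of the 4 values shown sits.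

The compounds shown leave open whether a different group on this aromatic carbon, such as a morpholine ring, a primary amine or a carboxylic acid, would shift inhibition in this assay by more than the usual scatter. Also open, going by these compounds, is whether the swap would give a readable step on a related compound whose starting value lies well clear of the assay's limit, where a change in either direction could be measured as a number.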